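A few compounds are considered here, and "the series" means these few. Any claim that something is new, unique, unknown or untested is made for them only; others in the source may bear on it.

Measured compounds:
compound 1 `CC[C@@H](Nc1c(C#N)c(-c2ccc(-c3ccc(F)cc3)cc2)nc2cnccc12)C(N)=O` gives 2.7
compound 2 `CCOc1ccccc1-c1ccc(-c2nc3cnccc3c(N[C@H](CC(C)C)C(N)=O)c2C#N)cc1` gives 3.4
compound 3 `CN(CC(N)=O)c1c(C#N)c(-c2ccc(Br)cc2)nc2cnccc12` gives 2.1

In a physicochemical assay for lipophilicity, read by HPLC, at pH 7.5 (a higher number here means a more lipophilic compound, a lower number a more polar compound), compound 1 stands second highest of the three numbers. Its nearest neighbour is compound 3, whose value of 2.1 lies lower by more than the scatter; furthest away is compound 2, whose value of 3.4 lies higher, again beyond the scatter. Compound 4 `CC[C@@H](Nc1c(C#N)c(-c2ccc(-c3cccc(Cl)c3)cc2)nc2cnccc12)C(N)=O` has not yet been measured in this assay. It differs from compound 1 in one place: 3-chlorophenyl in place of 4-fluorophenyl on an aromatic carbon. Among the compounds with values here, no measured pair shows this change directly. The step from compound 1 to compound 4 is expected to be a moderate rise, a number 0.40 log units higher from compound 1 to compound 4 (beyond the scatter), beyond the scatter. Compound 4 is therefore estimated at 3.1, within a range from 2.7 to 3.5.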

Compound 4, distribution coefficient: 3.1
For compound 4 middle estimate and measured number coincide at the digits printed; measured number inside the range.
By their numbers in this assay, from the lowest: compound 3; then compound 1; then compounds 4 and 2 (each within the scatter of the next).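

In this assay, the terminal ring on an aromatic carbon para to a large group gives its first direct reading: with the rest of compound 1 unchanged, 3-chlorophenyl in place of 4-fluorophenyl gives a number 0.40 log units higher from compound 1 to compound 4 (beyond the scatter) in a single swap of one ring for another. The earlier compounds shown here differ in several places at once, so none of them could isolate this position. Within the data shown here, this single pair shows that the read-out is sensitive to the group at this position, though it gives only one step in one direction.

A 4-chlorophenyl or 3-fluorophenyl group, or an amine on this ring, would show whether the step follows the halogen, its place on the ring or something else. Nothing presented here accounts for the step.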